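The source may report more compounds than this note shows. Statements on the series, on what has been measured and on what is new or still open speak of the compounds shown alone.

Measured so far:
- compound 1, `CCOC(=O)[C@H](CCC(=O)O)NC(=O)c1ccc(Sc2nc3cc(N)cc(N)c3nc2-c2ccccc2)cc1` — 33100 nM
- compound 2, `Nc1cc(N)c2nc(-c3ccccc3)c(Sc3ccc(F)cc3)nc2c1` — 15800 nM
- compound 3, `CCOC(=O)[C@H](CCC(=O)O)NC(=O)c1ccc(CNc2nc3cc(N)cc(N)c3nc2-c2ccccc2)cc1` — 45700 nM

In a functional assay on M14 cells (Homo sapiens) for inhibition, read by sulforhodamine B assay, with a stated time of 48 h (on this read-out lower numbers stand for stronger inhibition of growth and higher numbers for weaker inhibition of growth), compound 2 gives 15800 nM, the lowest of the three numbers; compound 1 stands beyond the scatter from it, and compound 3 further still. Compound 1 and compound 3 themselves lie within the scatter of each other, so their pair shows no difference that can be read.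

Compound 4, `Nc1cc(N)c2nc(-c3ccccc3)c(NCc3ccc(F)cc3)nc2c1`, is not yet measured. It differs from compound 2 in one place: (4-fluorobenzyl)amino in place of (4-fluorophenyl)sulfanyl on an aromatic carbon. Compound 1 and compound 3 carry the same two kinds of group at the same place, on a core that otherwise bears a longer side chain, and their two values sit within the scatter. Among the measured compounds shown here, no measured step isolates this change, so the expectation rests on that pair alone.

For compound 4 in this assay a step of a 1.4-fold higher number from compound 2 to compound 4 (0.14 log units; within the scatter) is expected, a mild rise if any, not clearly beyond the scatter. Compound 4 is therefore estimated at 22000 nM, with a range from 8000 nM to 60000 nM.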

Compound 4, concentration for 50% growth inhibition: 23400 nM
Estimate against measurement, compound 4: 1.1-fold (0.03 log units) below, and the stated range covers the measured number.
By their numbers in this assay, from the lowest: compounds 2, 4, 1 and 3 (each within the scatter of the next, the first and the last beyond it).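

In this assay, the change from (4-fluorophenyl)sulfanyl to (4-fluorobenzyl)amino on this aromatic carbon gives a 1.5-fold higher number from compound 2 to compound 4 (0.17 log units; within the scatter), so at this position the read-out does not separate the two groups. Among the compounds shown here, this is the first reading of the change as a single step on the shared core, without the longer side chain of compound 1 and compound 3, and the hydrogen-bond donor that enters with the (4-fluorobenzyl)amino group brings no readable difference. No measurement at hand explains why this step stays so small.

Still open, from the compounds shown here alone, is how an ether oxygen or a plain amine as the link to the fluorophenyl ring would read at this position. Also open, going by these compounds, is whether a carboxylic acid or a longer alkyl chain in place of the fluorine would leave the number as unchanged.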